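The compounds below may be only part of what the source reports. "The series", "measured", "known", "first", "only" and "open" are said of these compounds alone.

Compound 3 `COc1ccccc1C(=O)NC(=S)NNc1ncnc2ccccc12` stands highest in a functional assay on MGC-803 cells (Homo sapiens) for cytotoxicity, read by MTT assay, with a stated time of 72 h (a higher number here means a weaker inhibitor, a lower number a stronger inhibitor), among the three measured compounds: compound 3 gives 14300 nM, while compound 1 `COc1cc2ncnc(NNC(=S)NC(=O)c3ccccc3Cl)c2cc1OC` gives 6440 nM and compound 2 `COc1cc2ncnc(NNC(=S)NC(=O)c3ccccc3F)c2cc1OC` gives 2390 nM. The step from compound 3 to compound 4 `O=C(NC(=S)NNc1ncnc2ccccc12)c1cccc(Cl)c1` is 3-chlorophenyl in place of 2-methoxyphenyl on a carbonyl carbon. Among the measured compounds shown here, only one measured step exists, and it is of a different kind: it exchanges halogens on an aromatic carbon, and a 2.7-fold lower number from compound 1 to compound 2 (0.43 log units; beyond the scatter). For the measured compounds named here, no measured pair puts a methoxy group against a chlorine on the aryl ring, and no measured pair places a chlorine at the position it occupies in compound 4, so the size and direction of this change cannot be read off directly. Compound 1 and compound 3 differ in two places, so their values only show that compound 1 comes in lower than compound 3. On that basis the expectation is that compound 4 lands near compound 3 in this assay, with the step of a 1.4-fold lower number from compound 3 to compound 4 (0.16 log units; within the scatter) not clearly beyond the scatter in either direction. Compound 4 is therefore estimated at 10000 nM in this assay, with a range from 3000 nM to 35000 nM.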

Compound 4, half-maximal inhibitory concentration: 4540 nM
The estimate for compound 4 lay 2.2-fold (0.34 log units) above the measured number; the measured number falls inside the stated range.
By their numbers in this assay, from the lowest: compounds 2, 4 and 1 (each within the scatter of the next, the first and the last beyond it); then compound 3.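

On the core shared by compound 3 and compound 4, the aryl group on the carbonyl carbon proves to be a position where the read-out responds: putting 3-chlorophenyl in place of 2-methoxyphenyl gives a 3.1-fold lower number from compound 3 to compound 4 (0.50 log units; beyond the scatter) in this assay. Among the compounds shown here, the only earlier step, a 2.7-fold lower number from compound 1 to compound 2 (0.43 log units; beyond the scatter), exchanged one halogen for another on a different core and left the place of the substituent on the aryl ring unchanged, whereas this step changes the substituent and its place on the ring together, so it cannot be assigned to either change alone. Nothing at hand accounts for the step, and the result stands here as an observation only.

From the compounds shown here alone, it remains open whether the chlorine, its place on the ring or the loss of the methoxy group carries the step, and how an unsubstituted phenyl, or an aryl ring bearing an amine or a carboxylic acid, would read at this carbonyl carbon. Going by these compounds, it is equally open whether the same exchange would give a step of similar size and direction on the core of compound 1.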